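Replacing Piperidin-1-yl with 1,2-Thiazol-5-yl on the Shared Core

A few compounds are considered here, and "the series" means these few. Any claim that something is new, unique, unknown or untested is made for them only; others in the source may bear on it.

Compound 1 `CCC(C)(C)Cc1c[nH]c(CCc2ccc(-c3cnccn3)cc2)n1` gives 100 nM in a functional assay on HEK293 cells for agonist activity at Bombesin receptor subtype-3 (Homo sapiens), read by luminescence and calcium flux, with a stated time of 10 min; on this read-out lower numbers stand for an effect already at smaller amounts and higher numbers for an effect only at larger amounts of compound.
Compound 2 `CCC(C)(C)Cc1c[nH]c(CCc2ccc(N3CCCCC3)cc2)n1` gives 108 nM in this assay.
Compound 3 `O=C(O)c1cc(F)c(F)cc1-c1ccc(CCc2nc(CC3CCCCC3)c[nH]2)cc1` gives 103 nM in this assay.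

Compound 2 gives the highest of the three numbers, yet its gaps to compound 1 and to compound 3 both lie within the scatter, so the three cannot be told apart. Compound 4 `CCC(C)(C)Cc1c[nH]c(CCc2ccc(-c3ccns3)cc2)n1` differs from compound 2 by 1,2-thiazol-5-yl in place of piperidin-1-yl on an aromatic carbon. Within the data shown here, the only measured step at this place is a 1.1-fold higher number from compound 1 to compound 2 (0.03 log units; within the scatter), which exchanged one ring for another without a change beyond the scatter. Among the measured compounds shown here, no measured step involves 1,2-thiazol-5-yl, and no measured compound carries a five-membered aromatic ring there, so the expectation rests on that single step alone. The estimated step of a 1.0-fold lower number from compound 2 to compound 4 (0.01 log units; within the scatter) is expected to stay within the scatter. Compound 4 is therefore estimated at 105 nM, with a range from 45 nM to 250 nM.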

Compound 4, half-maximal effective concentration: 102 nM
Beside the measured number, compound 4's estimate is 1.0-fold (0.01 log units) above it; measured number inside the range.
By their numbers in this assay, from the lowest: compounds 1, 4, 3 and 2 (each within the scatter of the next).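

In this assay, putting 1,2-thiazol-5-yl in place of piperidin-1-yl gives a 1.1-fold lower number from compound 2 to compound 4 (0.02 log units; within the scatter), and putting it in place of pyrazin-2-yl gives a 1.0-fold higher number from compound 1 to compound 4 (0.01 log units; within the scatter). A five-membered aromatic ring can therefore sit at this place on the shared core, and the three rings there cannot be told apart by this read-out. Nothing available gives a reason for this sameness. Every compound shown carries a ring at this place. Going by these compounds, how a group without a ring, such as methoxy or dimethylamino, would read there remains open.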